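Swapping a quinoline for a biphenyl on the shared core

This account rests on a few compounds, and the source may have more. Where it says the series, first, only, none or still open, it means among the compounds named here.

Measured compounds:
compound 1 `CC1=C(C(=O)OCC2CCN(C(=O)OC(C)(C)C)CC2)C(c2cccc(C#N)c2)C2=C(CC(C)(C)CC2=O)N1` — 220 nM
compound 2 `CC1=C(C(=O)OCC2CCN(C(=O)OC(C)(C)C)CC2)C(c2cccc(C(C)C)c2)C2=C(CC(C)(C)CC2=O)N1` — 3320 nM
compound 3 `CC1=C(C(=O)OCC2CCN(C(=O)OC(C)(C)C)CC2)C(c2ccc3ccccc3n2)C2=C(CC(C)(C)CC2=O)N1` — 330 nM

All three share one core and differ only in the aromatic group on a saturated ring carbon. In an assay on HEK293 cells for inhibition of neurogenic locus notch homolog protein 1 (Homo sapiens), read by a luciferase reporter and resazurin assay, with a stated time of 16 h (on this read-out lower numbers stand for stronger inhibition and higher numbers for weaker inhibition), compound 3 gives 330 nM, the second highest of the three numbers. Its nearest neighbour is compound 1, which gives 220 nM; the step of a 1.5-fold higher number from compound 1 to compound 3 (0.18 log units; within the scatter) lies within the scatter, so the two cannot be ranked. Compound 2 is the outlier: the step of a 15-fold higher number from compound 1 to compound 2 (1.18 log units; beyond the scatter) is large, and the step of a 10-fold lower number from compound 2 to compound 3 (1.00 log units; beyond the scatter) recovers most of that loss.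

Compound 4 `CC1=C(C(=O)OCC2CCN(C(=O)OC(C)(C)C)CC2)C(c2ccc(-c3ccccc3)cc2)C2=C(CC(C)(C)CC2=O)N1` has not yet been measured. Its change from compound 3 is 4-phenylphenyl in place of quinolin-2-yl on a saturated ring carbon. Within the data shown here, the only step that touches the group on this saturated ring carbon and reaches beyond the scatter is a 10-fold lower number from compound 2 to compound 3 (1.00 log units; beyond the scatter), where compound 2 carries 3-isopropylphenyl. Compound 4 again carries a group without a hydrogen-bond acceptor, as the change describes, so a weaker result than compound 3 is expected, but with wide uncertainty.

The estimate for compound 4 is 1500 nM with a range from 400 nM to 6000 nM, an expected step of a 4.5-fold higher number from compound 3 to compound 4 (0.66 log units; beyond the scatter).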

Compound 4, half-maximal inhibitory concentration: > 10000 nM
Compound 4 ended at the assay's limit; the forecaster's own chance of this, stated with the estimate: 5%; middle value at least 6.6-fold (0.82 log units) from the limit.
By their numbers in this assay, from the lowest: compounds 1 and 3 (each within the scatter of the next); then compound 2. At a limit, above all of these: compound 4.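

The result for compound 4 in this assay is a limit of the assay and not a number: the limit of > 10000 nM in this assay, at which 1 of the 4 values shown sits.

Even so, all three new steps lie beyond the scatter: an at least 30-fold higher number from compound 3 to compound 4 (1.48 log units; beyond the scatter) and an at least 45-fold higher number from compound 1 to compound 4 (1.65 log units; beyond the scatter) are large, and an at least 3.0-fold higher number from compound 2 to compound 4 (0.47 log units; beyond the scatter) shows that 4-phenylphenyl on this saturated ring carbon does worse than 3-isopropylphenyl, the poorest group among the earlier compounds. Across the four compounds, the two groups with nitrogen, 3-cyanophenyl and quinolin-2-yl, give the lowest numbers, the two groups of carbon only, 3-isopropylphenyl and 4-phenylphenyl, give the highest, and no compound shown goes against this.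

The change from compound 3 to compound 4 removes the ring nitrogen and also alters the size and shape of the group, so these compounds cannot say which of these matters. Going by these compounds, a pyridinylphenyl group, which keeps two linked rings but restores a ring nitrogen, would help separate the two, and whether this position accepts an amine or a carboxylic acid on the aromatic ring remains open.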